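The source may report more compounds than this note shows. Statements on the series, on what has been measured and on what is new or still open speak of the compounds shown alone.

Measured in a functional assay on MOLT-3 cells (Homo sapiens) for antiproliferative activity; on this read-out higher numbers stand for weaker inhibition and lower numbers for stronger inhibition:
Compound 1 `COc1ccc(NC(=O)c2cc(NC(=O)C(C)Br)ccc2F)cc1`: 250 nM.
Compound 2 `CCOc1ccc(NC(=O)c2cc(NC(=O)C(C)Br)ccc2F)cc1`: > 10000 nM, a limit of the assay.

Going by the values given here, compound 1, at 250 nM, is the only compound here with an actual number. Compound 2 gives only a limit, > 10000 nM.

Compound 3 `COc1cc(NC(=O)c2cc(NC(=O)C(C)Br)ccc2F)ccn1` has not yet been measured. It keeps the core of compound 1 and swaps the group on the amide-type nitrogen, with 2-methoxypyridin-4-yl in place of 4-methoxyphenyl on an amide-type nitrogen.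

Among the compounds with values here, only one measured step bears on this change. It also falls on the 4-methoxyphenyl group of compound 1, although it is a different edit: an at least 40-fold higher number from compound 1 to compound 2 (1.60 log units; beyond the scatter). A large step there shows that this group can matter, so a moderate shift toward weaker inhibition is expected in this assay, because an at least 40-fold higher number from compound 1 to compound 2 (1.60 log units; beyond the scatter) ran that way. The expected step is a 2.4-fold higher number from compound 1 to compound 3 (0.38 log units; beyond the scatter). Compound 3 is estimated at 600 nM, with an expected range of 150 nM to 4000 nM.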

Compound 3, half-maximal inhibitory concentration: 500 nM
Estimate against measurement, compound 3: 1.2-fold (0.08 log units) above; low and high end bracket the measured number.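

In this assay, 2-methoxypyridin-4-yl in place of 4-methoxyphenyl on the amide-type nitrogen gives a 2.0-fold higher number from compound 1 to compound 3 (0.30 log units; within the scatter). The earlier pair showed only that an edit to this group, methyl in place of hydrogen on the methoxy carbon, could push the read-out to a limit; compound 3 shows that the aromatic ring here can carry a ring nitrogen, with one more hydrogen-bond acceptor, and still give a measured number that stays within the scatter of compound 1. The value of compound 2 remains a limit, not a number, so the true size of that earlier step stays unknown: the limit of > 10000 nM in this assay, at which 1 of the 3 values shown sits.

The compounds shown leave open how the read-out would respond to an amine or a carboxylic acid in place of the methoxy group on this ring. They also leave open whether a longer chain on the oxygen would behave like the ethoxy group of compound 2.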